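The compounds below may be only part of what the source reports. "The series", "measured", "known", "first", "only" and "open" are said of these compounds alone.

Within the data shown here, compound 2 `CCN(CCCn1cc[n+](C)c1/C=N/O)S(C)(=O)=O` is one of two compounds measured in a physicochemical assay for lipophilicity; on this read-out higher numbers stand for higher lipophilicity and lower numbers for lower lipophilicity. Among the measured compounds shown here, compound 2 gives -2.69, while compound 1 `CN(CCCn1cc[n+](C)c1/C=N/O)S(C)(=O)=O` gives -2.63; the step of a number 0.06 log units lower from compound 1 to compound 2 (within the scatter) is the only step measured so far, and it concerns a chain carbon rather than the sulfonyl sulfur. Compound 3 `CCN(CCCn1cc[n+](C)c1/C=N/O)S(=O)(=O)c1ccccc1` differs from compound 2 by phenyl in place of methyl on a sulfonyl sulfur. For the measured compounds named here, no measured step covers this kind of change. Because compound 2 gives -2.69, the estimate for compound 3 is -1.6, within -2.3 to -0.9, and the expected step is a number 1.09 log units higher from compound 2 to compound 3 (beyond the scatter) upward.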

Compound 3, distribution coefficient: -1.27
Compound 3: the middle estimate sits 0.33 log units below what was measured; the measured number falls inside the stated range.
By their numbers in this assay, from the lowest: compounds 2 and 1 (each within the scatter of the next); then compound 3.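

On the sulfonyl sulfur, phenyl in place of methyl gives a large change in this assay: a number 1.42 log units higher from compound 2 to compound 3 (beyond the scatter). Among these compounds, the only earlier step, on a saturated chain carbon, stayed within the scatter, so this is the first place where a single change clearly moves the read-out. Nothing available explains the size of this step.

Going by these compounds, it remains open whether ethyl or cyclohexyl on the sulfonyl sulfur would give a step of similar size. On these data alone, whether the same phenyl change would act alike on compound 1 also stays open.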